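The source may hold more compounds than are shown below. What is called first, only, known or untested is meant among the compounds shown, and "the series" means these compounds.

Measured so far in a functional assay on membranes from Sf9 cells for agonist activity at histamine H2 receptor (Homo sapiens), read by scintillation counting and GTPgammaS binding, with a stated time of 90 min; on this read-out higher numbers stand for larger maximal responses and lower numbers for smaller maximal responses:
compound 1 `CCCNC(=O)/N=C(\N)NCCCc1sc(N)nc1C` — 0.79
compound 2 `CCCCCCNC(=O)/N=C(\N)NCCCc1sc(N)nc1C` — 0.6
compound 3 `Cc1nc(N)sc1CCCN/C(N)=N/C(=O)NCC(C)C1CCCCC1` — 0.65

Compound 2 stands lowest of the three numbers in this assay; the gap to compound 3 is a number 0.050 higher from compound 2 to compound 3 (within the scatter), while compound 1 lies higher by a number 0.19 lower from compound 1 to compound 2 (beyond the scatter). Compound 4 `Cc1nc(N)sc1CCCN/C(N)=N/C(=O)Nc1ccccc1` differs from compound 2 in one place: phenyl in place of hexyl on an amide-type nitrogen. The measured steps all lengthen or branch the chain end, a number 0.19 lower from compound 1 to compound 2 (beyond the scatter) and a number 0.14 lower from compound 1 to compound 3 (beyond the scatter), each a modest loss; none swaps a chain for an aromatic ring, so they bear on this change only loosely. Compound 2 already carries the longest plain chain, and the replacement removes it without adding further chain; a small gain, or none beyond the scatter, seems the likeliest outcome in this assay. Expected, then, is a step of a number 0.080 higher from compound 2 to compound 4 (within the scatter), within the scatter. Compound 4 is estimated at 0.68, with a range from 0.52 to 0.84.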

Compound 4, intrinsic activity: the largest response reached, as a fraction of the reference agonist's: 0.59
Compound 4: the middle estimate sits 0.090 above what was measured; the measured number falls inside the stated range.
By their numbers in this assay, from the lowest: compounds 4, 2 and 3 (each within the scatter of the next); then compound 1.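

In this assay, an aromatic ring on the amide-type nitrogen reads no differently from the open hexyl chain of the same carbon count, with a number 0.010 lower from compound 2 to compound 4 (within the scatter). Phenyl in place of propyl gives a number 0.20 lower from compound 1 to compound 4 (beyond the scatter), so this loss is not confined to lengthened or branched saturated groups. Nothing shown gives a reason for either step. Open, as far as these compounds go, is whether benzyl or aminophenyl on this nitrogen would hold the response of compound 4, and whether methyl or ethyl would match compound 1.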